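Bromo for Trifluoromethyl: Expected Clearance of Compound 3

A few compounds are considered here, and "the series" means these few. Any claim that something is new, unique, unknown or untested is made for them only; others in the source may bear on it.

Compound 1 `Brc1cccc2c1nnn2CC1CC1`: 1.3 mL/min/g
Compound 2 `FC(F)(F)c1cc(Br)c2nnn(CC3CC3)c2c1`: 0.1 mL/min/g

Among the measured compounds shown here, in an ADME assay on microsomes from liver (Homo sapiens) for metabolic stability, tested at 2.5 uM (on this read-out higher numbers stand for fast clearance and lower numbers for slow clearance), compound 2 gives 0.1 mL/min/g, the lowest of the two numbers, with compound 1 as its only neighbour. For the measured compounds named here, the single measured step is a 13-fold lower number from compound 1 to compound 2 (1.11 log units; beyond the scatter). Compound 3 `Brc1cc(Br)c2nnn(CC3CC3)c2c1` has not been measured; (bromo in place of trifluoromethyl on an aromatic carbon). That step bears on the change only in part, since the trifluoromethyl leaves but bromo rather than hydrogen enters, so a rise smaller than the measured step is expected. Compound 3 is therefore expected at 0.3 mL/min/g, within 0.1 mL/min/g to 0.9 mL/min/g. This estimate means an expected step of a 3.0-fold higher number from compound 2 to compound 3 (0.48 log units; beyond the scatter).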

Compound 3, intrinsic clearance in a liver preparation (reported as CLH), per the amount of preparation that the assay uses: 0.6 mL/min/g
Beside the measured number, compound 3's estimate is 2.0-fold (0.30 log units) below it; the range from low to high includes it.
By their numbers in this assay, from the lowest: compound 2; then compound 3; then compound 1.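

In this assay, the position now proves open to more than one group: bromo in place of hydrogen also lowers the number (a 2.2-fold lower number from compound 1 to compound 3 (0.34 log units; beyond the scatter)), so a lower number than with hydrogen is not unique to trifluoromethyl. The two groups still differ clearly, with bromo in place of trifluoromethyl giving a 6.0-fold higher number from compound 2 to compound 3 (0.78 log units; beyond the scatter) and leaving compound 3 between the other two. Nothing available accounts for this difference between bromo and trifluoromethyl. Going by these compounds, whether a nitrile, a methoxy group or an amine on this aromatic carbon would also lower the number remains open, as does whether the order of these groups holds on another core.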